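The compounds below may be only part of what the source reports. "The series", "measured", "known", "first", "only" and "open" are said of these compounds alone.

In an ADME assay on HEK293 cells (Homo sapiens) for cytotoxicity, read by CCK-8 assay and cell counting, with a stated time of 2 days (on this read-out lower numbers stand for stronger inhibition and higher numbers for weaker inhibition), compound 1 `Oc1ccc(-c2cc(-c3cccnc3)nc(-c3cccc(Cl)c3)c2)cc1` gives 25700 nM. Compound 2 `Oc1ccc(-c2cc(-c3ccncc3)nc(-c3cccc(Cl)c3)c2)cc1` has no single number to stand on, as its entry reads "not determined" (no result reported). The next structure is compound 3 `Oc1ccc(-c2cc(-c3ccsc3)nc(-c3cccc(Cl)c3)c2)cc1`. The change thiophen-3-yl in place of pyridin-4-yl on an aromatic carbon puts thiophen-3-yl in place of pyridin-4-yl on an aromatic carbon. Among the measured compounds shown here, with no number for compound 2, the only guide is compound 1 at 25700 nM, so no step beyond the usual scatter of this assay is expected, in either direction. The estimated value for compound 3 is 20000 nM, with an expected range from 8000 nM to 50000 nM.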

Compound 3, half-maximal inhibitory concentration: 2670 nM
The estimate for compound 3 lay 7.5-fold (0.87 log units) above the measured number; measured number outside the range, below it.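

In this assay this position is sensitive to the ring placed on it: thiophen-3-yl in place of pyridin-3-yl gives a 9.6-fold lower number from compound 1 to compound 3 (0.98 log units; beyond the scatter), with the rest of the molecule unchanged. The step from compound 2 cannot be read, as that compound has no number. Nothing measured here explains the shift. The compounds shown leave open whether the sulfur-containing ring itself matters, as a plain phenyl or a furan-3-yl group at this position could tell. They also leave open how an amine or a carboxylic acid on this ring would read.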